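This account rests on a few compounds, and the source may have more. Where it says the series, first, only, none or still open, it means among the compounds named here.

In a functional assay on MCF-10A cells (Homo sapiens) for antiproliferative activity, with a stated time of 48 h (a lower number here means that less compound is needed, a higher number that more compound is needed for the effect), compound 2 `Cc1cc(NCc2ccc(F)cc2)c2ccccc2n1` gives 20100 nM. That number is not separated from compound 3 `COc1ccc2c(NCc3ccc(F)cc3)cc(C)nc2c1` at 15900 nM. Compound 1 `COc1ccc2nc(C)cc(NCc3ccc(C(C)(C)C)cc3)c2c1` gives 7000 nM, and the gap between this number and that of compound 2 exceeds the usual scatter. Compound 4 `CCCOc1ccc2nc(C)cc(NCc3ccc(F)cc3)c2c1` departs from compound 2 by propoxy in place of hydrogen on an aromatic carbon. Within the data shown here, the one measured step that bears on this change is a 1.3-fold lower number from compound 2 to compound 3 (0.10 log units; within the scatter), with methoxy in place of hydrogen on an aromatic carbon. On that evidence, only a slight move toward a lower number, not beyond the scatter, is expected in this assay. The expected step is a 1.4-fold lower number from compound 2 to compound 4 (0.16 log units; within the scatter). For compound 4 the estimated value is 14000 nM, with an expected range from 6500 nM to 30000 nM.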

Compound 4, half-maximal effective concentration: 14300 nM
The estimate for compound 4 lay 1.0-fold (0.01 log units) below the measured number; measured number inside the range.
By their numbers in this assay, from the lowest: compound 1; then compounds 4, 3 and 2 (each within the scatter of the next).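

In this assay, propoxy on this aromatic carbon gives a 1.4-fold lower number from compound 2 to compound 4 (0.15 log units; within the scatter), so this chain leaves compound 4 unseparated from compound 2. Among these compounds, the methoxy of compound 3 sits on a different aromatic carbon of the shared core, which makes this the first reading at this position. No measurement shown here accounts for the result. From the compounds shown here alone, whether an amine or a carboxylic acid on this carbon would give a number separated from that of compound 2 remains open. So does the outcome for a longer chain here.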